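Thioalkyl citrates: a second chloro on the ring

This account rests on a few compounds, and the source may have more. Where it says the series, first, only, none or still open, it means among the compounds named here.

In an assay on isolated protein for inhibition of ATP-citrate synthase (Rattus norvegicus) (on this read-out higher numbers stand for weaker inhibition and lower numbers for stronger inhibition), compound 1 `O=C(O)CC(O)(CSCCCCCCCCCc1ccc(Cl)cc1Cl)C(=O)O` gives 300000 nM, compound 2 `O=C(O)CC(O)(CSCCCCCCc1ccccc1Cl)C(=O)O` gives 69000 nM, and compound 3 `O=C(O)CC(O)(CSCCCCCCc1cccc(Cl)c1)C(=O)O` gives 150000 nM. Compound 3 stands second highest of the three numbers, nearer to compound 1 than to compound 2. Among the measured compounds shown here, the one measured step, a 2.2-fold higher number from compound 2 to compound 3 (0.34 log units; beyond the scatter), moves a single chloro group from one ring carbon to another rather than adding one. Compound 4 `O=C(O)CC(O)(CSCCCCCCc1cccc(Cl)c1Cl)C(=O)O` differs from compound 3 by chloro in place of hydrogen on an aromatic carbon. For the measured compounds named here, compound 1 also carries two chloro groups, but its chain is longer, so it supplies no clean single step. Going by the values given here, with no measured step that adds a chloro group, the step of a 1.3-fold lower number from compound 3 to compound 4 (0.10 log units; within the scatter) is expected to stay near the scatter. Compound 4 is therefore estimated at 120000 nM, with a range of 50000 nM to 300000 nM.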

Compound 4, inhibition constant: 7300 nM
Compound 4: the middle estimate sits 16-fold (1.22 log units) above what was measured; measured number below the stated range.
By their numbers in this assay, from the lowest: compound 4; then compound 2; then compounds 3 and 1 (each within the scatter of the next).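

Adding a second chloro to the ring, 3-chlorophenyl to 2,3-dichlorophenyl, gives a 21-fold lower number from compound 3 to compound 4 (1.31 log units; beyond the scatter), whereas moving a single chloro gave only a 2.2-fold higher number from compound 2 to compound 3 (0.34 log units; beyond the scatter). The same addition seen from the other single-chloro compound gives a 9.5-fold lower number from compound 2 to compound 4 (0.98 log units; beyond the scatter), so on this chain the 2,3-dichlorophenyl ring outperforms both single-chloro rings. No measurement at hand bears on the reason for this gain.

On these data alone, whether a bromo or methoxy group on the same ring carbon would match the second chloro remains open. So does the effect of a longer chain on the 2,3-dichlorophenyl ring, since compound 1 changes both chain and chloro pattern.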